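The source may hold more compounds than are shown below. What is called first, only, known or untested is meant among the compounds shown, and "the series" means these compounds.

- Compound 1 `Cc1ccnc2c1nc(C1CCC1)n2Cc1ccc(-c2ccccc2C(=O)O)cc1`: 5.01 nM
- Compound 2 `CSc1nc2c(C)ccnc2n1Cc1ccc(-c2ccccc2C(=O)O)cc1`: 10 nM

In a functional assay (aorta) with Oryctolagus cuniculus as the target (on this read-out lower numbers stand for tighter binding and higher numbers for weaker binding), compound 2 gives 10 nM, a number within the scatter of compound 1. Compound 3 `CCSc1nc2c(C)ccnc2n1Cc1ccc(-c2ccccc2C(=O)O)cc1` differs from compound 2 by methyl in place of hydrogen on a saturated chain carbon bound to a sulfur, which turns methylsulfanyl to ethylsulfanyl. Among the compounds with values here, only one measured step bears on this, and it is a different change, methylsulfanyl in place of cyclobutyl. With compound 2 reached by a 2.0-fold higher number from compound 1 to compound 2 (0.30 log units; within the scatter), no step beyond the scatter is expected in this assay. The expected move is a 1.3-fold lower number from compound 2 to compound 3 (0.10 log units; within the scatter). Compound 3 is estimated at 8 nM, with an expected range of 3 nM to 20 nM.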

Compound 3, dissociation constant: 5.01 nM
The estimate for compound 3 lay 1.6-fold (0.20 log units) above the measured number; low and high end bracket the measured number.
By their numbers in this assay, from the lowest: compounds 1, 3 and 2 (each within the scatter of the next).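

In this assay, turning methylsulfanyl into ethylsulfanyl leaves the number within the scatter (a 2.0-fold lower number from compound 2 to compound 3 (0.30 log units; within the scatter)), so this added methyl on a saturated chain carbon bound to a sulfur produces no readable step. Ethylsulfanyl also matches cyclobutyl on the aromatic carbon (no change at the digits printed from compound 1 to compound 3 (within the scatter)), so all three groups at this position now lie within the scatter of one another. As far as these compounds go, whether a longer chain on the sulfur or an amine at this position would stay within the scatter remains open. No measured evidence bears on why these groups read alike.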